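The source may report more compounds than this note shows. Statements on the series, on what has been measured and on what is new or still open speak of the compounds shown alone.

The measured compounds and their values:

Compound 1 `c1ccc(CN2CCC3(CC2)OCCc2c3csc2-c2ccccc2)cc1` gives 4.5 nM
Compound 2 `Cc1ccc(-c2scc3c2CCOC32CCN(Cc3ccccc3)CC2)cc1` gives 3.6 nM
Compound 3 `COC1Cc2c(csc2-c2ccccc2)C2(CCN(Cc3ccccc3)CC2)O1` gives 1 nM

All three were tested in an assay on membranes from brain for displacement of a labelled ligand from Sigma non-opioid intracellular receptor 1 (Cavia porcellus), read by scintillation counting, with a stated time of 120 min; on this read-out higher numbers stand for weaker inhibition and lower numbers for stronger inhibition. Compound 1 serves as the starting point. Compound 2 differs from it by one change, (methyl in place of hydrogen on an aromatic carbon), and the step it made is a 1.3-fold lower number from compound 1 to compound 2 (0.10 log units; within the scatter). Compound 3 differs from compound 1 by a different change, (methoxy in place of hydrogen on a saturated ring carbon), and here the step is a 4.5-fold lower number from compound 1 to compound 3 (0.65 log units; beyond the scatter). Compound 3 thus gives the lowest of the three numbers, and its distances to both compound 1 and compound 2 lie beyond the scatter.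

Compound 4 `COC1Cc2c(csc2-c2ccc(C)cc2)C2(CCN(Cc3ccccc3)CC2)O1` has not been measured. It differs from compound 3 by methyl in place of hydrogen on an aromatic carbon. This is the same change that separates compound 1 from compound 2, occurring twice among the compounds shown, and it sits at the same kind of place in both pairs. The two cores on which it is made differ by methoxy in place of hydrogen on a saturated ring carbon.

In this assay the step expected from compound 3 to compound 4 is a 1.3-fold lower number from compound 3 to compound 4 (0.10 log units; within the scatter), which rests on the measured step of a 1.3-fold lower number from compound 1 to compound 2 (0.10 log units; within the scatter) and on the small size of the methyl group entering. Compound 4 is therefore estimated to give 0.8 nM, with a likely range from 0.3 nM to 2.5 nM.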

Compound 4, inhibition constant: 2 nM
Compound 4: the middle estimate sits 2.5-fold (0.40 log units) below what was measured; the range from low to high includes it.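

In this assay, going from phenyl to 4-methylphenyl on the core that carries the methoxy gives a 2.0-fold higher number from compound 3 to compound 4 (0.30 log units; within the scatter), and this step cannot be told apart from the one the same change made on the core without the methoxy: the same change on two cores in this assay, a 1.3-fold lower number (0.10 log units; within the scatter) from compound 1 to compound 2 and a 2.0-fold higher number (0.30 log units; within the scatter) from compound 3 to compound 4, 2.5-fold (0.40 log units) apart, within the scatter of two such steps

Read the other way, placing methoxy on the saturated ring carbon of the compounds that already carry the methyl gives a 1.8-fold lower number from compound 2 to compound 4 (0.26 log units; within the scatter), and this step also cannot be told apart from its earlier counterpart, even though only the earlier one lies beyond the scatter: the same change on two cores in this assay, a 4.5-fold lower number (0.65 log units; beyond the scatter) from compound 1 to compound 3 and a 1.8-fold lower number (0.26 log units; within the scatter) from compound 2 to compound 4, 2.5-fold (0.40 log units) apart, within the scatter of two such steps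

So, within these four compounds, the methyl change carries from one core to the other without a difference that these measurements can detect, but this does not show that the two steps are truly equal, since a real gap smaller than the scatter would look the same, and one pair of cores cannot establish a rule for the whole series.

The compounds shown leave open what a chlorine atom, a nitrile or an amine would do in place of the methyl on the six-membered aromatic ring. They also leave open whether a longer chain in place of the methoxy would keep the number as low as that of compound 3, at 1 nM.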